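A few compounds are considered here, and "the series" means these few. Any claim that something is new, unique, unknown or untested is made for them only; others in the source may bear on it.

Compound 1 `CN1C[C@H](C(=O)Nc2ccccc2)[C@@H](c2ccc(/C=C/C(=O)Nc3ccccc3N)cc2)C1`: 67 mL/min/kg
Compound 2 `Cc1ccc(NC(=O)[C@H]2CN(C)C[C@@H]2c2ccc(/C=C/C(=O)Nc3ccccc3N)cc2)cc1`: 62 mL/min/kg
Compound 3 `CN1C[C@H](C(=O)Nc2cccnc2)[C@@H](c2ccc(/C=C/C(=O)Nc3ccccc3N)cc2)C1`: 41 mL/min/kg

Of the compounds shown here, three have so far been measured in an in vitro ADME assay on microsomes from liver (Mus musculus) for pharmacokinetics, read by LC-MS, with a stated time of 10 min, tested at 1 uM (on this read-out higher numbers stand for fast clearance and lower numbers for slow clearance), and in that read-out compound 1 gives 67 mL/min/kg, compound 2 gives 62 mL/min/kg and compound 3 gives 41 mL/min/kg. Compound 2 differs from compound 1 by methyl in place of hydrogen on an aromatic carbon, and this change made a step of a 1.1-fold lower number from compound 1 to compound 2 (0.03 log units; within the scatter). Compound 3 has a different core from compound 1, namely (pyridin-3-yl in place of phenyl on an amide-type nitrogen), with a step of a 1.6-fold lower number from compound 1 to compound 3 (0.21 log units; within the scatter); between compound 2 and compound 3 the step is a 1.5-fold lower number from compound 2 to compound 3 (0.18 log units; within the scatter).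

Compound 4 `Cc1ccc(NC(=O)[C@H]2CN(C)C[C@@H]2c2ccc(/C=C/C(=O)Nc3ccccc3N)cc2)cn1` has not yet been measured. It stands to compound 3 as compound 2 stands to compound 1: methyl in place of hydrogen on an aromatic carbon. The place is not identical, since in compound 1 the ring is one of carbon only, whereas in compound 3 it is a ring with 1 nitrogen and the methyl enters next to the ring nitrogen, so this counts as the same kind of change rather than the same one. Because the step of a 1.1-fold lower number from compound 1 to compound 2 (0.03 log units; within the scatter) stayed within the scatter, the step expected for compound 4, a 1.1-fold lower number from compound 3 to compound 4 (0.03 log units; within the scatter), is estimated to be of the same small size, resting on that single precedent. Compound 4 is therefore estimated at 38 mL/min/kg in this assay, with an expected range from 22 mL/min/kg to 66 mL/min/kg.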

Compound 4, clearance: 57 mL/min/kg
Compound 4: middle estimate off by 1.5-fold (0.18 log units), on the low side; the range from low to high includes it.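

In this assay the methyl change on the ring with 1 nitrogen gave a 1.4-fold higher number from compound 3 to compound 4 (0.14 log units; within the scatter), and set beside its earlier instance on the all-carbon ring it shows no real difference between the two cores: the same change on two cores in this assay, a 1.1-fold lower number (0.03 log units; within the scatter) from compound 1 to compound 2 and a 1.4-fold higher number (0.14 log units; within the scatter) from compound 3 to compound 4, 1.5-fold (0.18 log units) apart, within the scatter of two such steps. The other new steps, a 1.1-fold lower number from compound 2 to compound 4 (0.04 log units; within the scatter) and a 1.2-fold lower number from compound 1 to compound 4 (0.07 log units; within the scatter), are also within the scatter, so compound 4 cannot be told apart from compound 1 or compound 2 on clearance. For the compounds shown here, this shows that, across these two cores, putting methyl in place of hydrogen produced no step beyond the scatter, but with only one pair per core it does not show that the change is without effect, and it does not show that the same would hold on any other core.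

The compounds shown carry only hydrogen or methyl at this place, on only two kinds of ring. Going by these compounds, whether a chlorine atom, a methoxy group, an amine or a longer alkyl chain there would shift clearance beyond the scatter remains open.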